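Three phenol analogues and a methyl for methoxy swap

The source may report more compounds than this note shows. Statements on the series, on what has been measured and on what is new or still open speak of the compounds shown alone.

compound 1, `Cc1cc(C)c(O)c(-n2c(N)nc3ccccc32)c1`: 2.88 h
compound 2, `Cc1cc(O)c(-n2c(N)nc3ccccc32)cc1C`: 2.15 h
compound 3, `COc1ccc(-n2c(N)nc3ccccc32)c(O)c1`: 2.07 h

These three compounds share one core and were all run in an ADME assay on microsomes from liver (Homo sapiens) for metabolic stability, read by LC-MS, using NADPH, with a stated time of 60 min, tested at 1 uM; a higher number here means that the compound lasts longer, a lower number that the compound disappears faster. In this assay compound 1 gives 2.88 h, compound 2 gives 2.15 h and compound 3 gives 2.07 h. The three numbers sit close together: the gap from compound 3 to compound 2 and the gap from compound 3 to compound 1 are each within the usual scatter, so compound 3 cannot be told apart from either of them on these data. No pair of these compounds differs in only one place, so no single structural step has yet been measured.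

Compound 4, `Cc1ccc(-n2c(N)nc3ccccc32)c(O)c1`, has not been measured in this assay. It is reached from compound 3 by one change: methyl in place of methoxy on an aromatic carbon. Among the compounds with values here, with no measured step to lean on, the size of the change can only be guessed from the narrow spread of compound 1, compound 2 and compound 3. A small step, not clearly beyond the scatter, is expected from compound 3 to compound 4, a 1.4-fold higher number from compound 3 to compound 4 (0.13 log units; within the scatter), if anything towards a longer half-life. Compound 4 is therefore estimated at 2.8 h, with a range from 1.4 h to 5.5 h.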

Compound 4, half-life in the Homo sapiens assay: 2.7 h
Compound 4: the middle estimate sits 1.0-fold (0.02 log units) above what was measured, within the range that was stated.
By their numbers in the Homo sapiens assay, from the lowest: compounds 3, 2, 4 and 1 (each within the scatter of the next).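

In the Homo sapiens assay methyl in place of methoxy on an aromatic carbon gives a 1.3-fold higher number from compound 3 to compound 4 (0.12 log units; within the scatter) and hydrogen in place of methyl on an aromatic carbon gives a 1.3-fold higher number from compound 2 to compound 4 (0.10 log units; within the scatter) so the series now has its first steps in one place, and neither separates the compounds on half-life. In a physicochemical assay for solubility, read by nephelometry, measured as kinetic solubility, with a stated time of 30 min, at pH 7.4 (on this read-out lower numbers stand for lower solubility and higher numbers for higher solubility), compound 3 gives 50 ug/mL and compound 4 gives 25 ug/mL so the change from methoxy to methyl, on the carbon meta to a hydroxy group and para to a large group, also stays within the scatter on solubility. No measurement among those shown accounts for these readings.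

The compounds shown leave open whether an amine, a carboxylic acid or a longer chain on that same aromatic carbon would move either read-out beyond the scatter. They also leave open what happens when the hydroxy group is replaced, for instance by a methoxy group, since all four compounds carry it.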